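Lengthening a Hydroxyalkyl Chain: Expected Effect on Binding

The source may report more compounds than this note shows. Statements on the series, on what has been measured and on what is new or still open speak of the compounds shown alone.

Among the compounds with values here, compound 3 `CCCn1c(=O)n(CCO)c(=O)c2[nH]cnc21` gives 50000 nM in an assay on Cerebral cortex for binding affinity to adenosine receptor A1 (Cavia porcellus), read by radioligand binding (on this read-out higher numbers stand for weaker inhibition and lower numbers for stronger inhibition), the highest of the three numbers measured so far. Compound 2 `CCCn1c(=O)n(CCCN(C)C)c(=O)c2[nH]cnc21` gives 43200 nM, and a 1.2-fold higher number from compound 2 to compound 3 (0.06 log units; within the scatter). Compound 1 `CCCn1c(=O)n(CCN(C)C)c(=O)c2[nH]cnc21` gives 4300 nM, and a 12-fold higher number from compound 1 to compound 3 (1.07 log units; beyond the scatter). Compound 4 `CCCn1c(=O)n(CCCO)c(=O)c2[nH]cnc21` differs from compound 3 by hydroxymethyl in place of hydroxy on a saturated chain carbon, two bonds along the chain from an aromatic nitrogen. The measured step that bears most directly on this change is the same lengthening applied to a different group: a 10-fold higher number from compound 1 to compound 2 (1.00 log units; beyond the scatter). A weakening of similar or smaller size is therefore expected for compound 4, although compound 3 is already weak and the assay may report only a limit. Compound 4 is expected to give 100000 nM, with a range from 35000 nM to 300000 nM. This corresponds to an expected step of a 2.0-fold higher number from compound 3 to compound 4 (0.30 log units; within the scatter).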

Compound 4, inhibition constant: 12000 nM
Compound 4: the middle estimate sits 8.3-fold (0.92 log units) above what was measured; measured number below the stated range.
By their numbers in this assay, from the lowest: compound 1; then compound 4; then compounds 2 and 3 (each within the scatter of the next).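

In this assay the added chain carbon helps when the chain ends in hydroxy, with a 4.2-fold lower number from compound 3 to compound 4 (0.62 log units; beyond the scatter) and not the loss seen with dimethylamino in a 10-fold higher number from compound 1 to compound 2 (1.00 log units; beyond the scatter) here. On the longer chain, hydroxy now outperforms dimethylamino, with a 3.6-fold lower number from compound 2 to compound 4 (0.56 log units; beyond the scatter) as the step, yet the best number stays with the shorter dimethylamino chain, with a 2.8-fold higher number from compound 1 to compound 4 (0.45 log units; beyond the scatter) as the step. The swap from dimethylamino to hydroxy therefore has no fixed effect at this position, and its direction changes with chain length: the same change on two cores in this assay, a 12-fold higher number (1.07 log units; beyond the scatter) from compound 1 to compound 3 and a 3.6-fold lower number (0.56 log units; beyond the scatter) from compound 2 to compound 4, 42-fold (1.62 log units) apart, beyond the scatter of two such steps.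

Going by these compounds, whether a still longer chain ending in hydroxy would continue this gain remains open. So does how a primary amine or a carboxylic acid at the chain end would compare.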